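A Nitro Group Enters the Core of Compound 1

A few compounds are considered here, and "the series" means these few. Any claim that something is new, unique, unknown or untested is made for them only; others in the source may bear on it.

Compound 1 `c1cncc(N2CC[C@@H]3CN[C@@H]3C2)c1` is the more potent of the two compounds measured: in a functional assay on HEK293 cells for agonist activity at Neuronal acetylcholine receptor; alpha3/beta4 (Homo sapiens), read by FLIPR (a lower number here means that less compound is needed, a higher number that more compound is needed for the effect), compound 1 gives 260 nM, the lowest of the two numbers on hand. Its nearest neighbour is compound 2 `COc1cncc(N2CC[C@@H]3CN[C@@H]3C2)c1`, which in this assay gives 4500 nM; the step is a 17-fold higher number from compound 1 to compound 2 (1.24 log units; beyond the scatter) for methoxy in place of hydrogen on an aromatic carbon.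

Compound 3 `O=[N+]([O-])c1ccc(N2CC[C@@H]3CN[C@@H]3C2)cn1` differs from compound 1 by nitro in place of hydrogen on an aromatic carbon. Going by the values given here, the only measured step that bears on this change is a 17-fold higher number from compound 1 to compound 2 (1.24 log units; beyond the scatter), which is large, yet it concerns a different group at a different place, so it is a weak guide. Among the compounds with values here, no nitro-bearing compound has been measured. Since the one substitution on this ring seen so far raised the number markedly, a rise is expected here as well, with wide uncertainty.

Compound 3 is therefore expected to show a 7.7-fold higher number from compound 1 to compound 3 (0.89 log units; beyond the scatter). Compound 3 is estimated at 2000 nM, within a range from 400 nM to 10000 nM.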

Compound 3, half-maximal effective concentration: 830 nM
Compound 3: the middle estimate sits 2.4-fold (0.38 log units) above what was measured, and the stated range covers the measured number.
By their numbers in this assay, from the lowest: compound 1; then compound 3; then compound 2.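

In this assay, nitro on an aromatic carbon, next to the ring nitrogen and para to a group of 8 heavy atoms, brings a 3.2-fold higher number from compound 1 to compound 3 (0.50 log units; beyond the scatter). Going by these compounds alone, this is the first view of a substituent at this place and of a nitro group: the change carries a modest cost that lies beyond the scatter, and compound 1 keeps the lowest number of the three. Nothing on hand explains this step.

Going by these compounds, whether the rise belongs to nitro itself or would come with any group at this place stays open; an amine on the same carbon would help tell the two apart. The methoxy of compound 2 sits at a different place on the ring, so what the two groups do cannot be set directly against each other.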